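A few compounds are considered here, and "the series" means these few. Any claim that something is new, unique, unknown or untested is made for them only; others in the source may bear on it.

Measured in a functional assay on PC-3 cells (Homo sapiens) for cytotoxicity, read by MTT assay, with a stated time of 72 h; on this read-out lower numbers stand for stronger inhibition and higher numbers for weaker inhibition:
compound 1 `N#Cc1sc(N2CCCC2)nc1Cl`: > 100000 nM, a limit.
compound 2 `COC(=O)c1sc2nc(SC)sc2c1C`: 90000 nM.
compound 3 `COC(=O)c1sc2nc(N3CCCC3)sc2c1C`: > 100000 nM, a limit.

Compound 3 has no number on this scale, only the limit > 100000 nM. This is the limit of > 100000 nM in this assay, at which 2 of the 3 values shown sit.

Compound 4 `COC(=O)c1sc2nc(N3CCCCC3)sc2c1C` brings piperidin-1-yl in place of pyrrolidin-1-yl on an aromatic carbon. Going by the values given here, one measured step bears on this place: an at least 1.1-fold higher number from compound 2 to compound 3 (0.04 log units; that floor lies within the scatter). On these data alone, that step exchanges a different group, and its true size stays open. No step beyond the scatter is therefore expected in this assay, and the expected step is a number no higher from compound 3 to compound 4 (the limit leaves the size open). Another limit reading is the likeliest outcome. For compound 4 the estimated value is 100000 nM, with an expected range of 40000 nM to 200000 nM.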

Compound 4, half-maximal inhibitory concentration: 93000 nM
Estimate against measurement, compound 4: 1.1-fold (0.03 log units) above, and the stated range covers the measured number.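

In this assay, going by these compounds alone, piperidin-1-yl gives the first number on the scale for a ring amine at this position, and the exchange against methylsulfanyl shows a 1.0-fold higher number from compound 2 to compound 4 (0.01 log units; within the scatter). The step from the pyrrolidin-1-yl limit reads an at least 1.0-fold lower number from compound 3 to compound 4 (0.03 log units; that floor lies within the scatter), a floor that leaves the true size open. Readings at this position stay at the top of the scale: the limit of > 100000 nM in this assay, at which 2 of the 4 values shown sit.

On these data alone, whether morpholin-4-yl or piperazin-1-yl at this position moves the number clearly away from that limit stays open. So does the effect of a carboxylic acid in place of the methyl ester.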